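Swapping the end group on a chalcone-like core

The source may hold more compounds than are shown below. What is called first, only, known or untested is meant among the compounds shown, and "the series" means these compounds.

Of the compounds shown here, three sharing one core have been measured so far. Compound 1 `CCOc1ccc(C(=O)/C=C/c2ccc(N(C)C)cc2)cc1` carries a dimethylamino group at one end; in an assay on isolated protein for inhibition of Amine oxidase [flavin-containing] B (Homo sapiens) (a lower number here means a stronger inhibitor, a higher number a weaker inhibitor), compound 1 gives 210 nM. Compound 2 `CCOc1ccc(C(=O)/C=C/c2ccc(C)cc2)cc1` carries a methyl group in that position, and in this assay compound 2 gives 210 nM. Compound 3 `CCOc1ccc(C(=O)/C=C/c2ccc(CC)cc2)cc1` carries an ethyl group, and in this assay compound 3 gives 210 nM, level with the other two at the digits shown. The measured steps confirm this: no change at the digits printed from compound 1 to compound 2 (within the scatter), no change at the digits printed from compound 1 to compound 3 (within the scatter), and no change at the digits printed from compound 2 to compound 3 (within the scatter).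

Compound 4 `CCOc1ccc(C(=O)/C=C/c2ccc(C(F)(F)F)cc2)cc1` is not yet measured. It differs from compound 3 by trifluoromethyl in place of ethyl on an aromatic carbon. All three measured steps changed the group in this same position, and none of them moved this assay beyond the scatter, so the expectation is again a step of no real size: no change at the digits printed from compound 3 to compound 4 (within the scatter) is the change expected. Compound 4 is therefore estimated at 210 nM in this assay, with a range from 100 nM to 450 nM.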

Compound 4, half-maximal inhibitory concentration: 210 nM
The estimate for compound 4 equals the measured number at the digits printed; measured number inside the range.
By their numbers in this assay, from the lowest: compounds 1, 2, 3 and 4 (each within the scatter of the next).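

Trifluoromethyl is the first group at this position to carry fluorine, and it holds more heavy atoms than the ethyl it replaces, yet this assay shows no change at the digits printed from compound 3 to compound 4 (within the scatter). The comparisons with the other two end groups read the same: no change at the digits printed from compound 2 to compound 4 (within the scatter), and no change at the digits printed from compound 1 to compound 4 (within the scatter). The position has now taken dimethylamino, methyl, ethyl and trifluoromethyl with no step beyond the scatter, so this change adds fluorine to the range of groups that leave the number in place.

Nothing available explains why the number holds steady across these groups. Still open, as far as these compounds go, is whether a carboxylic acid, a primary amine, a longer chain or plain hydrogen at this position would also leave the number in place, or whether one of them would finally move it.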